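Moving Chlorines Around a Dichlorophenyl Ring

This account rests on a few compounds, and the source may have more. Where it says the series, first, only, none or still open, it means among the compounds named here.

In an ADME assay on MT4 cells (Homo sapiens) for cytotoxicity, read by MTT assay (on this read-out lower numbers stand for higher toxicity in this test and higher numbers for lower toxicity in this test), compound 3 `O=C1c2ccccc2C(=O)N1CCOC(=S)N(C(=O)c1ccco1)c1ccc(Cl)c(Cl)c1` gives 100000 nM and stands level with compound 1 `O=C1c2ccccc2C(=O)N1CCOC(=S)N(C(=O)c1ccco1)c1cccc(Cl)c1Cl` at 100000 nM on the digits shown. Compound 2 `O=C1c2ccccc2C(=O)N1CCOC(=S)N(C(=O)c1ccco1)c1ccc(Cl)cc1Cl` gives > 100000 nM as a limit of the assay and not a number. Compound 4 `O=C1c2ccccc2C(=O)N1CCOC(=S)N(C(=O)c1ccco1)c1cc(Cl)cc(Cl)c1` differs from compound 3 in one place: 3,5-dichlorophenyl in place of 3,4-dichlorophenyl on an amide-type nitrogen is the whole change, with 3,5-dichlorophenyl in place of 3,4-dichlorophenyl on an amide-type nitrogen. Earlier swaps of one dichlorophenyl pattern for another are the guide here: one step (no change at the digits printed from compound 1 to compound 3 (within the scatter)) lies within the scatter, and two others (a number no lower from compound 1 to compound 2 (the limit leaves the size open)) and (a number no higher from compound 2 to compound 3 (the limit leaves the size open)) have no readable size. No step beyond the scatter is therefore expected in this assay (no change at the digits printed from compound 3 to compound 4 (within the scatter)). The estimated value for compound 4 is 100000 nM (expected range 50000 nM to 200000 nM).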

Compound 4, half-maximal cytotoxic concentration: > 100000 nM
Compound 4 ended at the assay's limit; the forecaster's own chance of this, stated with the estimate: 40%; the middle value lies on the limit itself.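

The 3,5-dichlorophenyl group adds a fourth arrangement of the two chlorines on the amide-type nitrogen and gives a number no lower from compound 3 to compound 4 (the limit leaves the size open). Compound 4 ends at a limit of the assay, not at a number. In place of 2,3-dichlorophenyl, the same group gives a number no lower from compound 1 to compound 4 (the limit leaves the size open). The steps to compound 4 from compound 1, compound 2 and compound 3 cannot be read in size, because they run into a limit: the limit of > 100000 nM in this assay, at which 2 of the 4 values shown sit. Moving the chlorines around this ring has so far shown no readable change in this assay.

Still open, going by these compounds, is whether an amine or a carboxylic acid on this ring would give a readable number in this assay.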